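Notes on the step from compound 3 to compound 4

A few compounds are considered here, and "the series" means these few. Any claim that something is new, unique, unknown or untested is made for them only; others in the source may bear on it.

- compound 1 `Cc1ccsc1-c1cc(-c2ccco2)cc(-c2ccccc2Cl)n1`: 540 nM
- compound 2 `Clc1ccc(-c2cc(-c3ccco3)cc(-c3ccc(Cl)s3)n2)cc1`: 1080 nM
- compound 3 `Cc1ccc(-c2cc(-c3ccoc3)cc(-c3ccc(Cl)s3)n2)o1`: 790 nM

All three values come from a functional assay on HCT-15 cells (Homo sapiens) for cytotoxicity, read by ELISA, with a stated time of 4 days; on this read-out lower numbers stand for stronger inhibition and higher numbers for weaker inhibition. On these numbers compound 3, at 790 nM, sits in the middle of the set, within the scatter of both compound 1 and compound 2.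

The next compound is compound 4 `Clc1ccc(-c2cc(-c3ccoc3)cc(-c3ccccn3)n2)s1`, which carries pyridin-2-yl in place of 5-methylfuran-2-yl on an aromatic carbon, next to the ring nitrogen: pyridin-2-yl in place of 5-methylfuran-2-yl on an aromatic carbon. Going by the values given here, no measured pair differs in one place only, so the data hold no direct measure of such a change. Compound 3 at 790 nM lies within the scatter of the other two compounds even though it differs from them in more than one place. In this assay no step beyond the scatter is therefore expected, and neither direction is favoured. The estimated step is a 1.1-fold higher number from compound 3 to compound 4 (0.06 log units; within the scatter). For compound 4 the estimated value is 900 nM, with an expected range of 320 nM to 2800 nM.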

Compound 4, half-maximal inhibitory concentration: 1270 nM
Compound 4: the middle estimate sits 1.4-fold (0.15 log units) below what was measured; the measured number falls inside the stated range.
By their numbers in this assay, from the lowest: compounds 1, 3, 2 and 4 (each within the scatter of the next, the first and the last beyond it).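

In this assay, going by these compounds alone, a 1.6-fold higher number from compound 3 to compound 4 (0.21 log units; within the scatter) is the first reading of a change in one place only: pyridin-2-yl in place of 5-methylfuran-2-yl on an aromatic carbon, next to the ring nitrogen. At this position, a six-membered aromatic ring with 1 hetero atom and a five-membered aromatic ring with 1 hetero atom therefore cannot be told apart on this read-out, at least with the 5-chlorothiophen-2-yl and furan-3-yl groups in place. No measurement at hand bears on why this is so.

Going by these compounds, whether an amine such as piperidine or a carboxylic acid on this carbon would give a step beyond the scatter remains open. Also open, on these data alone, is whether the same exchange reads alike when another group stands in place of the furan-3-yl group.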